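The source may report more compounds than this note shows. Statements on the series, on what has been measured and on what is new or still open speak of the compounds shown alone.

The three measured compounds, with their results in a functional assay, with a stated time of 30 min, in the absence of a further agent; a higher number here means a weaker inhibitor, a lower number a stronger inhibitor:

compound 1, `O=C(Nc1nnc(-c2cccc(O)c2O)s1)c1ccc(Cl)cc1`: 30200 nM
compound 2, `O=C(Nc1nnc(-c2ccc(O)c(O)c2)s1)c1ccc(Cl)cc1`: 53000 nM
compound 3, `CC(=O)Nc1nnc(-c2cccc(O)c2O)s1`: 111000 nM

Compound 1 and compound 2 are built from the same atoms joined differently; the difference between the two cores is not broken down here. Their two results lie within the usual scatter of each other, so no order between them can be read from these numbers. Compound 3 differs from compound 1 in one place: methyl in place of 4-chlorophenyl on a carbonyl carbon. That change produced a 3.7-fold higher number from compound 1 to compound 3 (0.57 log units; beyond the scatter), a step beyond the scatter, so the smaller amide group weakened inhibition in this assay.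

Compound 4, `CC(=O)Nc1nnc(-c2ccc(O)c(O)c2)s1`, has not yet been measured. It stands to compound 2 as compound 3 stands to compound 1: methyl in place of 4-chlorophenyl on a carbonyl carbon. The two changes sit at the same kind of place, a carbonyl carbon whose other neighbour is an amide-type nitrogen, so this is the same change made on the core of compound 2 instead of the core of compound 1. Among the compounds shown this change appears only in these pairs, and only the pair from compound 1 to compound 3 has been measured, so that example is the only guide.

The expectation for compound 4 is therefore a step of about the size seen before, a 3.6-fold higher number from compound 2 to compound 4 (0.55 log units; beyond the scatter), starting from compound 2, because the earlier pair gave a 3.7-fold higher number from compound 1 to compound 3 (0.57 log units; beyond the scatter). On that basis compound 4 is estimated at 190000 nM, expected to fall between 80000 nM and 450000 nM.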

Compound 4, half-maximal inhibitory concentration: 23400 nM
Estimate against measurement, compound 4: 8.1-fold (0.91 log units) above; the measured number lies below the stated range.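

In this assay, the swap of methyl in place of 4-chlorophenyl on a carbonyl carbon now gave a 2.3-fold lower number from compound 2 to compound 4 (0.36 log units; beyond the scatter), so here the smaller group went with stronger inhibition, the opposite of what it did on the core of compound 1. Among these compounds, the change therefore does not carry over from one core to the other with a fixed size, or even a fixed direction, and the two steps are clearly different: the same change on two cores in this assay, a 3.7-fold higher number (0.57 log units; beyond the scatter) from compound 1 to compound 3 and a 2.3-fold lower number (0.36 log units; beyond the scatter) from compound 2 to compound 4, 8.3-fold (0.92 log units) apart, beyond the scatter of two such steps This shows that the effect of the change depends on the core it is made on, but with only two pairs it cannot tell why the cores respond differently, and it gives no rule for any further core.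

The compounds shown carry only methyl or 4-chlorophenyl on the carbonyl carbon, so it remains open how a plain phenyl, a longer chain such as propyl, or a cyclohexyl group would behave on each core. On these data alone, it is also open whether the two cores would keep parting ways with such groups, or whether the opposite steps seen here are limited to this one pair of groups.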